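Hydrazone series: halophenyl swap on the imine carbon

This account rests on a few compounds, and the source may have more. Where it says the series, first, only, none or still open, it means among the compounds named here.

Working notes on the shared core. In an assay on isolated protein for inhibition of Amine oxidase [flavin-containing] A (Homo sapiens), read by spectrophotometry (a lower number here means a stronger inhibitor, a higher number a weaker inhibitor), compound 1 `Clc1ccccc1/C=N/Nc1nc2ccccc2nc1Cc1ccccc1` gives 5.8 nM; compound 2 `C/C(=N\Nc1nc2ccccc2nc1Cc1ccccc1)c1ccc(N)cc1` gives 9.8 nM in this assay, and the two numbers sit within the scatter of each other, so neither is set apart. Compound 3 `Brc1cccc(/C=N/Nc2nc3ccccc3nc2Cc2ccccc2)c1` is the next member, not yet measured. Compound 3 differs from compound 1 by 3-bromophenyl in place of 2-chlorophenyl on a carbon with a double bond to nitrogen. Among the measured compounds shown here, no measured step separates these two halophenyl patterns, so the expectation for compound 3 is a step from compound 1 of a 1.4-fold higher number from compound 1 to compound 3 (0.14 log units; within the scatter), no more than the scatter in either direction. Compound 3 is estimated at 8 nM, with a range from 2.5 nM to 25 nM.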

Compound 3, half-maximal inhibitory concentration: 9.8 nM
Beside the measured number, compound 3's estimate is 1.2-fold (0.09 log units) below it; measured number inside the range.
By their numbers in this assay, from the lowest: compounds 1, 2 and 3 (each within the scatter of the next).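

In this assay, 3-bromophenyl in place of 2-chlorophenyl on a carbon with a double bond to nitrogen gives a 1.7-fold higher number from compound 1 to compound 3 (0.23 log units; within the scatter) and so does not set the two halophenyl patterns apart. Among the compounds shown here, this is the first measured step at this position, and it changes the halogen and its ring position together, so neither change can be read alone. No measured evidence bears on this result.

Still open, on these data alone, is whether a halophenyl group is needed here at all. An unsubstituted phenyl, or a phenyl carrying a carboxylic acid or a nitrile, would test this.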